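Lengthening the hydroxamate-bearing ester chain in this series

The source may report more compounds than this note shows. Statements on the series, on what has been measured and on what is new or still open speak of the compounds shown alone.

Compound 1 `O=C(O)c1ccc2c(c1)no[n+]2[O-]` is the acid of the series; in a functional assay on HeLa cells (Homo sapiens) for inhibition, read by MTT assay, with a stated time of 48 h (a lower number here means a stronger inhibitor, a higher number a weaker inhibitor), compound 1 stands at "not determined" (no result reported), so no number for it is available. Its ester compound 2 `O=C(CCCOC(=O)c1ccc2c(c1)no[n+]2[O-])NO` gives 17000 nM in this assay, while the longer-chain compound 3 `O=C(CCCCCOC(=O)c1ccc2c(c1)no[n+]2[O-])NO` gives 17300 nM. On the two numbers available compound 3 holds the higher one, with compound 2 its nearest neighbour, and the step of a 1.0-fold higher number from compound 2 to compound 3 (0.01 log units; within the scatter) lies within the scatter. Compound 4 `O=C(CCCCCCCOC(=O)c1ccc2c(c1)no[n+]2[O-])NO` extends the chain in the same manner: 2-(hydroxycarbamoyl)ethyl in place of hydroxycarbamoyl on a saturated chain carbon, five bonds along the chain from an oxygen next to a carbonyl group. For the measured compounds named here, the only measured step that bears on this change is the one from compound 2 to compound 3, and on that basis the step of a 1.0-fold higher number from compound 3 to compound 4 (0.00 log units; within the scatter) is expected to stay within the scatter. For compound 4 a value of 17500 nM is estimated, within a range of 9000 nM to 35000 nM.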

Compound 4, half-maximal inhibitory concentration: 5310 nM
Beside the measured number, compound 4's estimate is 3.3-fold (0.52 log units) above it, and the stated range ends above it.
By their numbers in this assay, from the lowest: compound 4; then compounds 2 and 3 (each within the scatter of the next).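

In this assay the length of this chain now matters: 2-(hydroxycarbamoyl)ethyl in place of hydroxycarbamoyl, five bonds along the chain from an oxygen next to a carbonyl group, gives a 3.3-fold lower number from compound 3 to compound 4 (0.51 log units; beyond the scatter) and thus a step beyond the scatter, which the earlier extension did not give. Measured against the shortest chain, the whole extension reads a 3.2-fold lower number from compound 2 to compound 4 (0.51 log units; beyond the scatter) and so rests on the last extension alone. No measurement shown here accounts for this drop. As far as these compounds go, whether a longer chain than that of compound 4 lowers the number further remains open, as does whether a carboxylic acid in place of the hydroxycarbamoyl end keeps the effect.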